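The compounds below may be only part of what the source reports. "The series", "measured", "known", "first", "only" and "open" are said of these compounds alone.

Within the data shown here, compound 1 `O/N=C(/Nc1cccc(Br)c1)c1ccc2occc2c1` is the only compound with a full number in an assay on isolated protein for inhibition of Indoleamine 2,3-dioxygenase 1 (Homo sapiens), read by spectrophotometry; on this read-out higher numbers stand for weaker inhibition and lower numbers for stronger inhibition: in this assay compound 1 gives 440 nM. Compound 2 `O/N=C(/Nc1cccc(Cc2ccccc2)c1)c1ccc2occc2c1` reaches only a limit of the assay, > 30000 nM in this assay. That single measured step, an at least 68-fold higher number from compound 1 to compound 2 (1.83 log units; beyond the scatter), swaps benzyl for bromo and is the limit of > 30000 nM in this assay, at which 1 of the 2 values shown sits, at its far end. Compound 3 `COCc1cc2cc(/C(=N\O)Nc3cccc(Br)c3)ccc2o1` differs from compound 1 in another way: methoxymethyl in place of hydrogen on an aromatic carbon. The bromo of compound 1 stays untouched, and the change lies on the fused two-ring core, so the measured step from compound 1 to compound 2 offers no direct guide. With no evidence on this position, the expectation is a step of no more than the usual scatter, in no firm direction. Compound 3 is therefore estimated at 450 nM, with a range from 150 nM to 1500 nM. The expected step is a 1.0-fold higher number from compound 1 to compound 3 (0.01 log units; within the scatter).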

Compound 3, half-maximal inhibitory concentration: 930 nM
Estimate against measurement, compound 3: 2.1-fold (0.32 log units) below; the measured number falls inside the stated range.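

The position on the five-membered aromatic ring, next to the ring oxygen, accepts methoxymethyl in place of hydrogen at a modest cost, giving a 2.1-fold higher number from compound 1 to compound 3 (0.33 log units; beyond the scatter) in this assay. A change on the shared core, with the bromo left in place, therefore does shift the number, yet compound 3 still gives a full value rather than a limit. Among these compounds, compound 2 remains the only compound at a limit of the assay: the limit of > 30000 nM in this assay, at which 1 of the 3 values shown sits.

Going by these compounds, a single group says little about this position as a whole, so it stays open whether a methyl, a longer chain, an amine or a carboxylic acid there would keep the number close to that of compound 1. Also open, on these data alone, is whether methoxymethyl would cost the same with chloro in place of the bromo.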